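A Dimethoxyphenyl Variant in a Hydrazone Series

A few compounds are considered here, and "the series" means these few. Any claim that something is new, unique, unknown or untested is made for them only; others in the source may bear on it.

Three hydrazone-linked compounds built on one shared core have been tested in an assay on isolated protein for inhibition of Maltase-glucoamylase (Homo sapiens), with a stated time of 15 min; on this read-out higher numbers stand for weaker inhibition and lower numbers for stronger inhibition. Compound 1 `COc1ccc(O)c(/C=N/NC(=O)c2ccc(-c3nc4ccccc4s3)cc2)c1` gives 6500 nM, compound 2 `O=C(N/N=C\c1ccccn1)c1ccc(-c2nc3ccccc3s2)cc1` gives 10200 nM, and compound 3 `COc1ccc(/C=N/NC(=O)c2ccc(-c3nc4ccccc4s3)cc2)c(O)c1` gives 6970 nM. On these numbers compound 3 stands second highest of the three: its nearest neighbour is compound 1 and its furthest is compound 2, and both gaps lie within the scatter. Within the data shown here, the single step between measured compounds that differ in one place is a 1.1-fold higher number from compound 1 to compound 3 (0.03 log units; within the scatter), which moves nothing beyond the scatter.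

Compound 4 `COc1cc(/C=N/NC(=O)c2ccc(-c3nc4ccccc4s3)cc2)cc(OC)c1` has not yet been measured. It differs from compound 3 by 3,5-dimethoxyphenyl in place of 2-hydroxy-4-methoxyphenyl on a carbon with a double bond to nitrogen. The step from compound 1 to compound 3 bears on this only in part, since both of those compounds keep the hydroxyl, whereas compound 4 carries no hydrogen-bond donor; compound 2 likewise carries none and gives 10200 nM, within the scatter of compound 3. Nothing measured therefore points to a step far from compound 3, and the step expected in this assay is a 1.2-fold higher number from compound 3 to compound 4 (0.09 log units; within the scatter). For compound 4 the estimate in this assay is 8500 nM, with a range from 3000 nM to 25000 nM.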

Compound 4, half-maximal inhibitory concentration: 16200 nM
Compound 4: the middle estimate sits 1.9-fold (0.28 log units) below what was measured, within the range that was stated.
By their numbers in this assay, from the lowest: compounds 1, 3, 2 and 4 (each within the scatter of the next, the first and the last beyond it).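

In this assay, among these compounds, the change to 3,5-dimethoxyphenyl on a carbon with a double bond to nitrogen is the first at this position to go beyond the scatter, with a 2.3-fold higher number from compound 3 to compound 4 (0.37 log units; beyond the scatter) and a 2.5-fold higher number from compound 1 to compound 4 (0.40 log units; beyond the scatter), whereas the exchange of the two hydroxyl-bearing groups, a 1.1-fold higher number from compound 1 to compound 3 (0.03 log units; within the scatter), stayed within it. The change has more than one part: 2-hydroxy-4-methoxyphenyl has 1 hydrogen-bond donor and 9 heavy atoms, 3,5-dimethoxyphenyl has 0 hydrogen-bond donors and 10 heavy atoms, and the hydrogen-bond acceptors stay at 2, so the step shows that this position responds to the change without showing which part of the change matters. No measurement at hand gives a reason for the higher number.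

The compounds shown do not separate the loss of the hydroxyl from the arrival of the second methoxy, and a plain phenyl or a dihydroxyphenyl group at this place would bear directly on that question. As far as these compounds go, how this position would respond to a group of another kind, such as an amine or a carboxylic acid on the phenyl ring, also remains open.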